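Removing a Methyl from the Amine: Cytotoxicity Outlook

The source may hold more compounds than are shown below. What is called first, only, known or untested is meant among the compounds shown, and "the series" means these compounds.

Measured compounds:
compound 1 `CC(C)n1ncc2c(C(=O)NCCCN(C)C)cc(C3CC3)nc21` gives > 200000 nM
compound 2 `CNCCCNC(=O)c1cc(C2CC2)nc2c1cnn2C(C)C` gives 281000 nM
compound 3 `Cc1nn(C(C)(C)C)c2nc(C3CC3)cc(C(=O)NCCN(C)C)c12` gives 56300 nM

All three were tested in an ADME assay on Vero cells (Chlorocebus sabaeus) for cytotoxicity, read by neutral red uptake, with a stated time of 3 days; on this read-out lower numbers stand for higher toxicity in this test and higher numbers for lower toxicity in this test. For compound 1 the result > 200000 nM is a limit of the assay rather than a number. Compound 2 differs from compound 1 by hydrogen in place of methyl on an amine nitrogen. In this assay compound 2 gives 281000 nM. The step that the limit leaves unreadable from compound 1 to compound 2 cannot be sized because compound 1 sits at the limit of > 200000 nM in this assay, at which 1 of the 3 values shown sits. Compound 3 carries a different core, and the difference between the two cores is not broken down here; in this assay compound 3 gives 56300 nM, the lowest of the two readable numbers.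

Compound 4 `CNCCNC(=O)c1cc(C2CC2)nc2c1c(C)nn2C(C)(C)C` has not yet been measured. It differs from compound 3 by hydrogen in place of methyl on an amine nitrogen, the same change at the same place as from compound 1 to compound 2. Since that earlier step gave no readable size, the expected step of a 1.3-fold higher number from compound 3 to compound 4 (0.12 log units; within the scatter) rests only on compound 2 giving 281000 nM and is estimated to be small. Compound 4 is therefore expected to give about 75000 nM, plausibly between 25000 nM and 250000 nM.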

Compound 4, half-maximal cytotoxic concentration: 36800 nM
Compound 4: middle estimate off by 2.0-fold (0.31 log units), on the high side; the range from low to high includes it.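

In this assay, putting hydrogen in place of methyl on the amine nitrogen gives a 1.5-fold lower number from compound 3 to compound 4 (0.18 log units; within the scatter), so on the core of compound 3, dimethylamino and methylamino cannot be told apart in this test. Compound 1 gives > 200000 nM, which is a limit of the assay and not a number. The step from compound 1 to compound 2 therefore cannot be read, leaving only one sized example of this change, so the series shows neither that its effect carries from one core to the other nor that it fails to: the limit of > 200000 nM in this assay, at which 1 of the 4 values shown sits.

The compounds shown leave open what a primary amine would give at the same place, with hydrogen in place of both methyl groups on the nitrogen. They also leave open whether replacing the amine with a carboxylic acid would shift the number by more than the usual scatter on either core.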